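Methoxy to chloro on a shared core, tested twice

The source may hold more compounds than are shown below. What is called first, only, known or untested is meant among the compounds shown, and "the series" means these compounds.

Compound 1 `COc1ccc(C2=Nn3c(nnc3C(C)c3ccc(-c4ccccc4)c(F)c3)SC2)cc1` gives 2600 nM in a functional assay on MCF7 cells (Homo sapiens) for inhibition, read by sulforhodamine B assay, with a stated time of 72 h; a higher number here means a weaker inhibitor, a lower number a stronger inhibitor. Compound 3 `CC(c1ccc(-c2ccccc2)c(F)c1)c1nnc2n1N=C(c1ccc(Cl)cc1)CS2` differs from it in one place, (chloro in place of methoxy on an aromatic carbon), and in this assay compound 3 gives 8700 nM, a step of a 3.3-fold higher number from compound 1 to compound 3 (0.52 log units; beyond the scatter). Compound 2 `COc1ccc(C2=Nn3c(nnc3C(C)c3ccc4cc(OC)ccc4c3)SC2)cc1` sits on a core whose difference from that of compound 1 is not broken down here; in this assay compound 2 gives 6600 nM. Within the data shown here, compound 4 `COc1ccc2cc(C(C)c3nnc4n3N=C(c3ccc(Cl)cc3)CS4)ccc2c1` has not been measured; it differs from compound 2 by chloro in place of methoxy on an aromatic carbon, the same change at the same kind of place as the one from compound 1 to compound 3. Among the measured compounds shown here, the step expected from compound 2 is a 2.7-fold higher number from compound 2 to compound 4 (0.44 log units; beyond the scatter), resting on the single earlier instance a 3.3-fold higher number from compound 1 to compound 3 (0.52 log units; beyond the scatter). Compound 4 is therefore estimated at 18000 nM, between 7000 nM and 45000 nM.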

Compound 4, half-maximal inhibitory concentration: 10100 nM
For compound 4 the middle estimate is 1.8-fold (0.25 log units) above the measured one, and the stated range covers the measured number.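

In this assay, the change from 4-methoxyphenyl to 4-chlorophenyl on the core of compound 2 gives a 1.5-fold higher number from compound 2 to compound 4 (0.18 log units; within the scatter), so on this core the step cannot be told from the scatter. The two steps cannot be told apart either: the same change on two cores in this assay, a 3.3-fold higher number (0.52 log units; beyond the scatter) from compound 1 to compound 3 and a 1.5-fold higher number (0.18 log units; within the scatter) from compound 2 to compound 4, 2.2-fold (0.34 log units) apart, within the scatter of two such steps. This shows no measurable dependence of the change on the core, but two instances, one of them within the scatter, do not show that the step has a fixed size or that it would carry over to any further core.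

The compounds shown leave open how the step behaves on other cores in the series. They also leave open what an amine or a nitrile would give at the same place on the ring.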